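Fluoro to trifluoromethyl step in a growth-inhibition series

The source may hold more compounds than are shown below. What is called first, only, known or untested is meant among the compounds shown, and "the series" means these compounds.

Measured compounds:
Compound 1 `Fc1ccc(-c2ccc(-c3ccc(-c4nc5ccccc5[nH]4)cc3)cc2)cc1`: 29700 nM
Compound 2 `FC(F)(F)c1ccc(-c2ccc(-c3ccc(-c4nc5ccccc5[nH]4)cc3)cc2)cc1`: 100000 nM
Compound 3 `Cc1ccc2[nH]c(-c3ccc(-c4ccc(-c5ccc(F)cc5)cc4)cc3)nc2c1`: 41000 nM

All three were run in a functional assay on SiHa cells (Homo sapiens) for inhibition, read by sulforhodamine B assay; a higher number here means a weaker inhibitor of growth, a lower number a stronger inhibitor of growth. Compound 1 gives 29700 nM in this assay, and compound 2, which carries the change (trifluoromethyl in place of fluoro on an aromatic carbon), gives 100000 nM; the step is a 3.4-fold higher number from compound 1 to compound 2 (0.53 log units; beyond the scatter). Compound 3 differs from compound 1 by methyl in place of hydrogen on an aromatic carbon, and in this assay compound 3 gives 41000 nM, a step of a 1.4-fold higher number from compound 1 to compound 3 (0.14 log units; within the scatter), so the methyl on the core leaves the number essentially where compound 1 stands.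

Compound 4 `Cc1ccc2[nH]c(-c3ccc(-c4ccc(-c5ccc(C(F)(F)F)cc5)cc4)cc3)nc2c1` has not yet been measured. It differs from compound 3 by trifluoromethyl in place of fluoro on an aromatic carbon, the same change that separates compound 2 from compound 1, and it sits on the core of compound 3 rather than the core of compound 1. Among the measured compounds shown here, that core difference has so far cost little, seen in a 1.4-fold higher number from compound 1 to compound 3 (0.14 log units; within the scatter), so the one prior example of the fluoro to trifluoromethyl change is the main guide. For the measured compounds named here, the step from compound 3 to compound 4 is therefore expected to be about a 2.4-fold higher number from compound 3 to compound 4 (0.39 log units; beyond the scatter) in this assay, resting on a 3.4-fold higher number from compound 1 to compound 2 (0.53 log units; beyond the scatter) as the single precedent; one example is a thin basis, and the upper range of this assay may cap what is reported. On that basis compound 4 is estimated at 100000 nM in this assay, with a plausible range from 45000 nM to 220000 nM.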

Compound 4, concentration for 50% growth inhibition: 33200 nM
Beside the measured number, compound 4's estimate is 3.0-fold (0.48 log units) above it, outside the stated range (below it).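

In this assay, the fluoro to trifluoromethyl change does not carry over from the core of compound 1 to the core of compound 3: on the latter it gives a 1.2-fold lower number from compound 3 to compound 4 (0.09 log units; within the scatter), and the comparison with the earlier step reads: the same change on two cores in this assay, a 3.4-fold higher number (0.53 log units; beyond the scatter) from compound 1 to compound 2 and a 1.2-fold lower number (0.09 log units; within the scatter) from compound 3 to compound 4, 4.2-fold (0.62 log units) apart, beyond the scatter of two such steps Seen from the other direction, the methyl on the core gives a 3.0-fold lower number from compound 2 to compound 4 (0.48 log units; beyond the scatter) when trifluoromethyl is present, which does not match its step when fluoro is present: the same change on two cores in this assay, a 1.4-fold higher number (0.14 log units; within the scatter) from compound 1 to compound 3 and a 3.0-fold lower number (0.48 log units; beyond the scatter) from compound 2 to compound 4, 4.2-fold (0.62 log units) apart, beyond the scatter of two such steps These four compounds therefore show that the two changes do not add in this assay, but they form a single comparison, so they show neither the reason for the mismatch nor whether it extends to any other compound in the series.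

Still open, as far as these compounds go, is what happens when a nitrile, an amine or a carboxylic acid replaces fluoro on the same aromatic carbon, and whether the outcome again depends on the methyl on the core. Also open, from the compounds shown here alone, is whether a longer chain such as ethyl or propyl in place of that methyl gives the same mismatch with fluoro and trifluoromethyl.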